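A Fluorophenyl Sulfonamide in Place of a Dimethylphenyl Analogue

The compounds below may be only part of what the source reports. "The series", "measured", "known", "first", "only" and "open" are said of these compounds alone.

Measured compounds:
compound 1 `Cc1ccc(C)c(S(=O)(=O)NCCCCCCNCc2ccc(Br)cc2)c1` — 12000 nM
compound 2 `O=S(=O)(NCCCNCc1ccc(Cl)cc1)c1cc(C(F)(F)F)cc(C(F)(F)F)c1` — 2800 nM
compound 3 `O=S(=O)(NCCNCc1ccc(-c2ccccc2)cc1)c1cc(C(F)(F)F)cc(C(F)(F)F)c1` — 2700 nM

In a functional assay on MIA PaCa-2 cells (Homo sapiens) for inhibition, read by MTT assay, with a stated time of 72 h (a lower number here means a stronger inhibitor of growth, a higher number a weaker inhibitor of growth), compound 1 gives 12000 nM, the highest of the three numbers; compound 2 and compound 3 both sit beyond the scatter below it, so compound 1 is the weakest growth inhibitor of the set. Compound 4 `O=S(=O)(NCCCCCCNCc1ccc(Br)cc1)c1ccccc1F` differs from compound 1 in one place: 2-fluorophenyl in place of 2,5-dimethylphenyl on a sulfonyl sulfur. No pair of measured compounds isolates this change, so nothing shown speaks to its size. The step of a 1.3-fold higher number from compound 1 to compound 4 (0.10 log units; within the scatter) is expected to stay within the scatter or amount to a slight weakening. Compound 4 is therefore estimated to give 15000 nM, within a range from 5000 nM to 40000 nM.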

Compound 4, concentration for 50% growth inhibition: 13300 nM
Compound 4: middle estimate off by 1.1-fold (0.05 log units), on the high side, and the stated range covers the measured number.
By their numbers in this assay, from the lowest: compounds 3 and 2 (each within the scatter of the next); then compounds 1 and 4 (each within the scatter of the next).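

In this assay, 2-fluorophenyl in place of 2,5-dimethylphenyl on a sulfonyl sulfur gives a 1.1-fold higher number from compound 1 to compound 4 (0.04 log units; within the scatter). Among the compounds shown here, this is the first comparison in the set that isolates a single place, and it shows that exchanging these two groups, with the rest of the core of compound 1 held fixed, leaves no difference that can be told from the scatter. No measured property of either group bears on this result. Still open, from the compounds shown here alone, is how this position responds to a different group, such as an aminophenyl or a carboxyphenyl.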